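Replacing the aryl amide on a triazole-linked chain

A few compounds are considered here, and "the series" means these few. Any claim that something is new, unique, unknown or untested is made for them only; others in the source may bear on it.

Measured so far:
compound 1 `Cn1c(Cc2nn(C)c(=O)c3ccccc23)nnc1SCCCCCC(=O)Nc1ccc(Cl)cc1Cl` gives 4100 nM in an assay on isolated protein (Mus musculus) for inhibition of IL15-IL15 receptor (Homo sapiens), read by resazurin assay, with stated times of 30 min and 2.5 days; a lower number here means a stronger inhibitor, a higher number a weaker inhibitor
compound 2 `Cn1c(Cc2nn(C)c(=O)c3ccccc23)nnc1SCCCCCCCCCCC(=O)Oc1ccc(Cl)cc1Cl` gives 8700 nM in this assay
compound 3 `CCCOc1ccc(NC(=O)CCCCCCCSc2nnc(Cc3nn(C)c(=O)c4ccccc34)n2C)cc1` gives 1600 nM in this assay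

Among these three numbers compound 3 has the lowest, and its steps to compound 1 and to compound 2 both lie beyond the scatter. Compound 4 `Cn1c(Cc2nn(C)c(=O)c3ccccc23)nnc1SCCCCCCCC(=O)Nc1ccccc1O` differs from compound 3 in one place: 2-hydroxyphenyl in place of 4-propoxyphenyl on an amide-type nitrogen. Within the data shown here, no measured pair differs by just this change, so the size of the step is uncertain. The chain and the shared core are unchanged. Compound 4 is expected to show a modest loss that may not exceed the scatter, an expected step of a 1.9-fold higher number from compound 3 to compound 4 (0.27 log units; within the scatter). Compound 4 is therefore estimated at 3000 nM, within a range from 1000 nM to 9000 nM.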

Compound 4, half-maximal inhibitory concentration: 27000 nM
Beside the measured number, compound 4's estimate is 9.0-fold (0.95 log units) below it; the whole stated range lies below it.
By their numbers in this assay, from the lowest: compound 3; then compound 1; then compound 2; then compound 4.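

Swapping 4-propoxyphenyl for 2-hydroxyphenyl on the amide-type nitrogen, with the chain unchanged, gives a 17-fold higher number from compound 3 to compound 4 (1.23 log units; beyond the scatter) in this assay, so inhibition depends strongly on the group at this position. The other step, a 6.6-fold higher number from compound 1 to compound 4 (0.82 log units; beyond the scatter), cannot be read as a single change, since the chain and the aromatic ring's substituents differ together. Nothing available here explains the loss.

Going by these compounds, whether the loss follows from gaining the hydroxy group or from losing the propoxy group remains open. Plain phenyl or 2-methoxyphenyl on this nitrogen would help separate the two.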